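The source may hold more compounds than are shown below. What is called first, only, known or untested is meant among the compounds shown, and "the series" means these compounds.

Measured so far in a physicochemical assay for lipophilicity, using the shake flask method, in phosphate buffer, measured as octanol-water partition, with a stated time of 30 min, at pH 7.4; a lower number here means a more polar compound, a higher number a more lipophilic compound:

- compound 1 `Cn1cc(-c2cnc(NCc3c(F)ccc4c3CCO4)c3cn[nH]c(=O)c23)cn1`: 2.7
- compound 2 `Fc1ccc2c(c1CNc1ncc(Oc3ccccc3)c3nncn13)CCO2`: 3.5
- compound 3 `Cc1ncc(-c2cnc(NCc3c(F)ccc4c3CCO4)c3cn[nH]c(=O)c23)n1C`: 1.9

Of these three, compound 2 stands highest at 3.5, with compound 1 and compound 3 both lower by more than the scatter. The next compound to be measured is compound 4 `CN(c1ccn(C)n1)c1cnc(NCc2c(F)ccc3c2CCO3)n2cnnc12`. It differs from compound 2 in one place, methyl(1-methyl-1H-pyrazol-3-yl)amino in place of phenoxy on an aromatic carbon.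

For the measured compounds named here, no measured step covers this exchange directly. Going by the values given here, the one measured step, a number 0.80 log units lower from compound 1 to compound 3 (beyond the scatter), exchanges one ring substituent for another on a different core and is modest, beyond the scatter. It shows that a single exchange of this kind can move the number appreciably. Compound 1 at 2.7 and compound 3 at 1.9 each carry a five-membered aromatic ring with 2 hetero atoms, and both read lower than compound 2, though their core differs.

A downward step of similar or slightly greater size is therefore expected, and the estimate is a number 1.00 log units lower from compound 2 to compound 4 (beyond the scatter). For compound 4 the expected value is 2.5. The estimated range for compound 4 runs from 2 to 3.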

Compound 4, distribution coefficient: 1.8
Estimate against measurement, compound 4: 0.70 log units above; measured number below the stated range.
By their numbers in this assay, from the lowest: compounds 4 and 3 (each within the scatter of the next); then compound 1; then compound 2.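

In this assay, the exchange of phenoxy for methyl(1-methyl-1H-pyrazol-3-yl)amino gives a number 1.70 log units lower from compound 2 to compound 4 (beyond the scatter), which shows that a single change at this aromatic carbon, para to a large group, can produce a large step. For the compounds shown here, the earlier compounds showed only a modest step, on a different core and at a different kind of exchange, so this is the first reading for this position on the core shared by compound 2 and compound 4. Nothing measured here explains the size of this step.

On these data alone, it remains open how much of the step belongs to the five-membered aromatic ring and how much to the methylated nitrogen link. An N-methylanilino group at the same carbon would separate these two parts, and a morpholine would show how a saturated ring compares.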